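Butyl versus fluorinated chains in the writhing series

A few compounds are considered here, and "the series" means these few. Any claim that something is new, unique, unknown or untested is made for them only; others in the source may bear on it.

Measured so far in a functional assay on the whole organism with Mus musculus as the target, in the writhing test (on this read-out higher numbers stand for an effect only at larger amounts of compound and lower numbers for an effect already at smaller amounts), as follows
compound 1 `CCCCSc1nsnc1C1CN2CCCC1C2` gives 0.03 mg/kg
compound 2 `FC(F)(F)CCCCSc1nsnc1[C@@H]1CN2CCC[C@@H]1C2` gives 0.07 mg/kg
compound 3 `FC(F)(F)CCSc1nsnc1[C@@H]1CN2CCC[C@@H]1C2` gives 0.1 mg/kg

Compound 3 at 0.1 mg/kg lies within the scatter of compound 2 and on the higher side of compound 1, beyond the scatter. The change to compound 4 (`CCCCSc1nsnc1[C@@H]1CN2CCC[C@@H]1C2`) is ethyl in place of trifluoromethyl on a saturated chain carbon, two bonds along the chain from a sulfur and reads ethyl in place of trifluoromethyl on a saturated chain carbon, two bonds along the chain from a sulfur. Within the data shown here, the only measured step at this place, a 1.4-fold higher number from compound 2 to compound 3 (0.15 log units; within the scatter), keeps the fluorines and so says little about removing them. Compound 1, which also bears butyl, gives 0.03 mg/kg and is the firmer guide. An expected step of a 3.3-fold lower number from compound 3 to compound 4 (0.52 log units; beyond the scatter) therefore points to lower numbers in this assay as the outcome. The estimate for compound 4 is 0.03 mg/kg (expected range 0.012 mg/kg to 0.08 mg/kg) in this read-out.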

Compound 4, dose for half-maximal effect: 0.19 mg/kg
Beside the measured number, compound 4's estimate is 6.3-fold (0.80 log units) below it; the whole stated range lies below it.
By their numbers in this assay, from the lowest: compound 1; then compounds 2, 3 and 4 (each within the scatter of the next, the first and the last beyond it).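

At this position, a 1.9-fold higher number from compound 3 to compound 4 (0.28 log units; within the scatter) in this assay, so ethyl in place of trifluoromethyl does not separate the two compounds on this read-out. Hydrogen in place of trifluoromethyl, four bonds along the chain from a sulfur, does separate them, with a 2.7-fold higher number from compound 2 to compound 4 (0.43 log units; beyond the scatter). Butyl alone therefore does not set the number, since a 6.3-fold higher number from compound 1 to compound 4 (0.80 log units; beyond the scatter) appears with the same atoms and bonds, and the one difference is in how the stereo elements are drawn: the fact that one of compounds 1 and 4 is drawn with a defined configuration and the other without, at the place where they differ

As far as these compounds go, how the opposite configuration of compound 4 reads in this assay remains open. So does whether a hexyl chain or a chain ending in a nitrile would hold these numbers on the shared core.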